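The source may report more compounds than this note shows. Statements on the series, on what has been measured and on what is new or still open speak of the compounds shown alone.

In a functional assay on COLO 205 cells (Homo sapiens) for inhibition, read by sulforhodamine B assay (on this read-out lower numbers stand for stronger inhibition of growth and higher numbers for weaker inhibition of growth), three compounds sharing one core have been measured so far. Compound 1 `c1ccc(-c2ccc(-c3ccc(-c4nc5ccccc5[nH]4)cc3)cc2)cc1` gives 100000 nM in this test. Compound 2 `FC(F)(F)Oc1ccc(-c2ccc(-c3ccc(-c4nc5ccccc5[nH]4)cc3)cc2)cc1` gives 100000 nM in the same test. Compound 3 `Oc1ccc(-c2ccc(-c3ccc(-c4nc5ccccc5[nH]4)cc3)cc2)cc1` gives 100000 nM and so stands level with the other two.

The next structure is compound 4 `COc1ccc(-c2ccc(-c3ccc(-c4nc5ccccc5[nH]4)cc3)cc2)cc1OC`, which has 3,4-dimethoxyphenyl in place of 4-hydroxyphenyl on an aromatic carbon, para to a large group (3,4-dimethoxyphenyl in place of 4-hydroxyphenyl on an aromatic carbon).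

Among the compounds with values here, three measured steps bear on this change, all made on the ring that changes here. Trifluoromethoxy in place of hydrogen gave no change at the digits printed from compound 1 to compound 2 (within the scatter) and hydroxy in place of hydrogen gave no change at the digits printed from compound 1 to compound 3 (within the scatter) in the same series. Hydrogen in place of trifluoromethyl on the oxygen gave no change at the digits printed from compound 2 to compound 3 (within the scatter) as well.

None of these steps moved the number, so no shift beyond the scatter is expected in this assay here. Within the data shown here, no measured compound carries two groups on that ring, so the lower end of the range is left wider.

The estimated change is no change at the digits printed from compound 3 to compound 4 (within the scatter) for this swap. For compound 4 the expected value is 100000 nM with an estimated range from 30000 nM to 130000 nM in this test.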

Compound 4, concentration for 50% growth inhibition: 41200 nM
The estimate for compound 4 lay 2.4-fold (0.39 log units) above the measured number; the measured number falls inside the stated range.
By their numbers in this assay, from the lowest: compound 4; then compounds 1, 2 and 3 (each within the scatter of the next).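

In this assay the ring at the end of the chain can shift the number after all: 3,4-dimethoxyphenyl gives a 2.4-fold lower number from compound 3 to compound 4 (0.39 log units; beyond the scatter) and also a 2.4-fold lower number from compound 1 to compound 4 (0.39 log units; beyond the scatter) in a step that is modest but beyond the scatter. Compound 2 with trifluoromethoxy and compound 3 with hydroxy go against any simple rule that groups on this ring help, since both stand level with the unsubstituted compound 1, so the gain belongs to this particular group and not to substitution as such. No evidence is available to explain the shift.

The compounds shown cannot tell whether a single methoxy group would do the same or whether both methoxy groups are needed. From the compounds shown here alone, how an amine or a carboxylic acid on this ring would read also stays open.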